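From Hydroxy to Chloro: Expecting Tolerability to Hold

A few compounds are considered here, and "the series" means these few. Any claim that something is new, unique, unknown or untested is made for them only; others in the source may bear on it.

Of the compounds shown here, three that share a sulfonamide-linked core have been tested in an ADME assay on HEK293 cells (Homo sapiens) for cytotoxicity, read by resazurin assay, with a stated time of 48 h; a higher number here means that more compound is tolerated, a lower number that less compound is tolerated. Compound 1 `O=S(=O)(Nc1ccc2oc(-c3ccccc3)nc2c1)c1ccc(O)cc1` gives > 100000 nM, which is a limit of the assay rather than a measured number. Compound 2 `O=S(=O)(Nc1ccc2oc(-c3ccccc3)nc2c1)c1ccc(F)c(C(F)(F)F)c1` likewise gives > 100000 nM, again a limit. Compound 3 `O=S(=O)(Nc1ccc(-c2nc3ccccc3o2)cc1)c1ccccc1Cl` gives > 100000 nM, also a limit. Compound 1 therefore stands where every tested compound stands, at the limit of > 100000 nM in this assay, at which 3 of the 3 values shown sit, and none of the three has yielded a number below that ceiling.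

Compound 4 `O=S(=O)(Nc1ccc2oc(-c3ccccc3)nc2c1)c1ccc(Cl)cc1` has not yet been tested. It differs from compound 1 in a single place: chloro in place of hydroxy on an aromatic carbon. Going by the values given here, no measured step between any two of the tested compounds is available, so the size of the change brought by such a swap cannot be read from the data. Because all three values rest at the limit of > 100000 nM in this assay, at which 3 of the 3 values shown sit, the expectation for compound 4 is no step beyond the usual scatter. The expected step is a number no higher from compound 1 to compound 4 (the limit leaves the size open). Compound 4 is estimated at 100000 nM, within a range from 30000 nM to 300000 nM.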

Compound 4, half-maximal cytotoxic concentration: 65000 nM
For compound 4 the middle estimate is 1.5-fold (0.19 log units) above the measured one, and the stated range covers the measured number.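

In this assay, chloro at this position gives the only actual number among the compounds shown, and the swap from hydroxy comes with an at least 1.5-fold lower number from compound 1 to compound 4 (0.18 log units; that floor lies within the scatter). The value for compound 1 is a limit, so the step has a floor but no known size, and the true gap could be wider than that floor or could stay close to it. The new number therefore shows that this single change on the shared core can yield a readable value, yet most of the set still sits at the ceiling: the limit of > 100000 nM in this assay, at which 3 of the 4 values shown sit.

As far as these compounds go, whether an amine, a methoxy group or a carboxylic acid at this place would also give a number rather than a limit stays open. So does whether fluoro or bromo would behave as chloro does here.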